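The compounds below may be only part of what the source reports. "The series", "measured", "known", "first", "only" and "open" are said of these compounds alone.

Measured compounds:
- compound 1, `Cc1cc(C)c(CN2CCc3c(Cl)cc([C@@H](CO)[C@@H]4CCOC4)c(Cl)c3C2=O)c(=O)[nH]1`: in an assay on cells for inhibition of histone-lysine N-methyltransferase EZH2 (Homo sapiens), read by ELISA, with a stated time of 72 h (a higher number here means a weaker inhibitor, a lower number a stronger inhibitor), compound 1 gives 2910 nM
- compound 2, `Cc1cc(C)c(CN2CCc3c(Cl)cc([C@@H](CO)[C@@H]4CCCO4)c(Cl)c3C2=O)c(=O)[nH]1`: compound 2 gives 1570 nM
- compound 3, `Cc1cc(C)c(CN2CCc3c(Cl)cc(-c4c(C)noc4C)c(Cl)c3C2=O)c(=O)[nH]1`: compound 3 gives 17 nM

Compound 3 carries the lowest number of the three. The step of a 92-fold lower number from compound 2 to compound 3 (1.97 log units; beyond the scatter) and the step of a 170-fold lower number from compound 1 to compound 3 (2.23 log units; beyond the scatter) are both beyond the scatter, so compound 3 is the strongest inhibitor of the measured set.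

Compound 4 is `Cc1cc(C)c(CN2CCc3c(Cl)cc([C@H](CO)[C@H]4CCOC4)c(Cl)c3C2=O)c(=O)[nH]1`. The change from compound 3 is a group of 8 heavy atoms (6 carbon, 2 oxygen; one five-membered non-aromatic ring with 1 hetero atom) in place of a group of 7 heavy atoms (5 carbon, 1 nitrogen, 1 oxygen; one five-membered aromatic ring with 2 hetero atoms), on an aromatic carbon. Among the compounds with values here, the entering group is the one carried by compound 1, with both of its defined stereocentres inverted.

Within the data shown here, the steps that bear on this change are the reverse of a 170-fold lower number from compound 1 to compound 3 (2.23 log units; beyond the scatter) and of a 92-fold lower number from compound 2 to compound 3 (1.97 log units; beyond the scatter), both large. The step of a 1.9-fold lower number from compound 1 to compound 2 (0.27 log units; within the scatter) is within the scatter, so the two oxolanyl variants sit close together. Among the measured compounds shown here, no measured pair shows what inverting the two stereocentres does, so that part is open; the expectation rests on the group swap alone, which in both measured cases moved the number by a large amount.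

An upward step of a 180-fold higher number from compound 3 to compound 4 (2.25 log units; beyond the scatter) is therefore expected. Compound 4 is estimated at 3000 nM, with a range of 700 nM to 13000 nM, the width reflecting the unknown contribution of the stereochemistry.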

Compound 4, half-maximal inhibitory concentration: 10 nM
The estimate for compound 4 lay 300-fold (2.48 log units) above the measured number, outside the stated range (below it).
By their numbers in this assay, from the lowest: compounds 4 and 3 (each within the scatter of the next); then compounds 2 and 1 (each within the scatter of the next).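

In this assay, the step of a 290-fold lower number from compound 1 to compound 4 (2.46 log units; beyond the scatter) has a single source: the fact that compounds 1 and 4 differ only in the configuration as drawn. At this aromatic carbon, ortho to a chloro group, the saturated oxolanyl group can therefore take the place of 3,5-dimethyl-1,2-oxazol-4-yl with no loss beyond the scatter, as a 1.7-fold lower number from compound 3 to compound 4 (0.23 log units; within the scatter) shows, so the aromatic ring is not required in this series and the large gaps seen earlier belong to one configuration rather than to the group swap as such. The oxolan-2-yl variant remains far from this level, at a 160-fold lower number from compound 2 to compound 4 (2.20 log units; beyond the scatter), but that step combines a change of ring attachment with a change of configuration and does not separate the two.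

Which of the two stereocentres accounts for the gap stays open, as does whether the oxolan-2-yl group would respond to inversion in the same way. Also open, as far as these compounds go, is whether the hydroxyl on the chain matters to the number in this assay, for instance whether an amine or a carboxylic acid at that end of the chain would keep it.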